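A few compounds are considered here, and "the series" means these few. Any claim that something is new, unique, unknown or untested is made for them only; others in the source may bear on it.

Three related compounds have a reading in a toxicity assay on cells (Epithelial cell, Homo sapiens) for cytotoxicity, read by MTT assay, with a stated time of 72 h; a higher number here means a weaker inhibitor, a lower number a stronger inhibitor. Compound 1 `C=CC(=O)N1CCC(Oc2nc(Nc3ccc(N(C)CCN(C)C)cc3OC)nc3[nH]ccc23)CC1` gives > 20000 nM, which is a limit of the assay and not a number. Compound 2 `C=CC(=O)N1CCC(Oc2nc(Nc3ccc(N4CCN(C)CC4)c(F)c3)nc3[nH]ccc23)CC1` gives 3020 nM. Compound 3 `C=CC(=O)N1CCC(Oc2nc(Nc3ccc(N4CCN(C)CC4)cc3OC)nc3ccsc23)CC1` gives 18600 nM, the higher of the two true numbers, and its gap to compound 2, its nearest neighbour on the scale, lies beyond the scatter. No two of these compounds differ in one place only, so the data hold no direct measure of any single change.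

Compound 4 `C=CC(=O)N1CCC(Oc2nc(Nc3ccc(N4CCN(C)CC4)cc3)nc3ccsc23)CC1` departs from compound 3 in a single place: hydrogen in place of methoxy on an aromatic carbon, ortho to a large group and meta to a 4-methylpiperazin-1-yl group (hydrogen in place of methoxy on an aromatic carbon). Among the measured compounds shown here, the only guide is indirect. For the measured compounds named here, compound 2, the one tested compound without a methoxy, gives 3020 nM, but it also differs from compound 3 elsewhere, so it supports only a cautious expectation. A modest move toward a lower number is expected in this assay, and the estimated step is a 2.1-fold lower number from compound 3 to compound 4 (0.32 log units; beyond the scatter). For compound 4 the expected value is 9000 nM, with an estimated range from 3500 nM to 20000 nM.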

Compound 4, half-maximal inhibitory concentration: 9050 nM
Estimate against measurement, compound 4: 1.0-fold (0.00 log units) below, and the stated range covers the measured number.
By their numbers in this assay, from the lowest: compound 2; then compound 4; then compound 3. At a limit, above all of these: compound 1.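

In this assay, among the compounds shown here, this pair gives the first direct reading of any single change among the compounds: hydrogen in place of methoxy on an aromatic carbon, ortho to a large group and meta to a 4-methylpiperazin-1-yl group, brings a 2.1-fold lower number from compound 3 to compound 4 (0.31 log units; beyond the scatter). The step is modest, but it shows that the methoxy at this place is not silent in this assay, and that on this core the number moves lower when the methoxy leaves. Both members of the pair give true numbers rather than a limit, so the step can be read in full and is not cut off at the top of the scale: the limit of > 20000 nM in this assay, at which 1 of the 4 values shown sits.

The compounds shown leave open whether other groups on this same aromatic carbon, such as ethoxy, chlorine or an amine, would take the number further down or back up, as only methoxy and hydrogen are compared here. Also open, on these data alone, is whether the same exchange would give a step of similar size on the core shared by compound 1 and compound 2.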